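Adding a methoxy to compound 2

This account rests on a few compounds, and the source may have more. Where it says the series, first, only, none or still open, it means among the compounds named here.

Of the compounds shown here, two sharing one core have been measured so far. In a functional assay on MDA-MB-435 cells (Homo sapiens) for inhibition, read by sulforhodamine B assay, with a stated time of 48 h, tested at 10 uM (on this read-out lower numbers stand for less inhibition of growth and higher numbers for more inhibition of growth at the one concentration tested), compound 1 `COc1ccc(-c2nc3sc(-c4ccccc4)cn3n2)cc1` gives -8.6% and compound 2 `Clc1ccc(-c2cn3nc(-c4ccccc4)nc3s2)cc1` gives 11%. Compound 2 therefore stands higher of the two, and the gap between them lies beyond the usual scatter of repeated measurements.

The next compound is compound 3 `COc1ccc(-c2nc3sc(-c4ccc(Cl)cc4)cn3n2)cc1`. It keeps the structure of compound 2 except for one change: methoxy in place of hydrogen on an aromatic carbon, para to a large group (methoxy in place of hydrogen on an aromatic carbon).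

Within the data shown here, no pair of measured compounds differs in one place only, so the size of such a change has not been seen directly. Compound 1 also carries a methoxy and stands at -8.6%, which offers no hint of a large rise. The expected result in this assay is therefore no shift beyond the scatter, with a slight drop estimated as a number 3 percentage points lower from compound 2 to compound 3 (within the scatter). For compound 3 the estimated value is 8%, with an expected range from -10% to 30%.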

Compound 3, percent growth inhibition at one concentration: 25%
For compound 3 the middle estimate is 17 percentage points below the measured one, and the stated range covers the measured number.
By their numbers in this assay, from the lowest: compound 1; then compound 2; then compound 3.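

In this assay methoxy in place of hydrogen on an aromatic carbon, para to a large group, brings a number 14 percentage points higher from compound 2 to compound 3 (beyond the scatter) and so gives the first direct view of this change: at this position the methoxy goes with more growth inhibition, not less. Compound 3 also gives the first direct view of a second change, since chloro in place of hydrogen on an aromatic carbon brings a number 33.6 percentage points higher from compound 1 to compound 3 (beyond the scatter) and shows that the methoxy alone does not set the number. The result also depends on the chloro. Nothing measured here bears on what lies behind either rise.

The compounds shown leave open whether the rise belongs to methoxy in particular or would also come with a hydroxyl, an amine or a longer chain such as ethoxy on the same aromatic carbon. They also leave open whether fluoro or bromo could stand in for the chloro, and whether either step would look the same at other concentrations.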